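Amino series: methyl on the ring nitrogen

The compounds below may be only part of what the source reports. "The series", "measured", "known", "first", "only" and "open" are said of these compounds alone.

Of the compounds shown here, three of the shared core have been tested in a functional assay on the whole organism for inhibition, with Rattus norvegicus as the target, at a dose of 0.3 mg/kg by the oral route; on this read-out higher numbers stand for a stronger effect at the one dose given and lower numbers for a weaker effect. Compound 1 `COc1ccc(-c2cccc(C(=O)Nc3nn[nH]n3)n2)cc1` gives 4%, compound 2 `Cc1ccc(-c2cccc(C(=O)Nc3nn[nH]n3)n2)cc1` gives 21%, and compound 3 `Nc1ccc(-c2cccc(C(=O)Nc3nn[nH]n3)n2)cc1` gives 11%. The step of a number 17 percentage points higher from compound 1 to compound 2 (beyond the scatter) is the only one beyond the scatter; the steps of a number 7 percentage points higher from compound 1 to compound 3 (within the scatter) and a number 10 percentage points lower from compound 2 to compound 3 (within the scatter) are not, so compound 3 is second highest of the three numbers but within the scatter of both neighbours. Compound 4 `CNc1ccc(-c2cccc(C(=O)Nc3nn[nH]n3)n2)cc1` differs from compound 3 by methyl in place of hydrogen on a nitrogen on an aromatic ring. Within the data shown here, no measured step touches the nitrogen; the two amino steps only show that compound 3 lies close to compounds 1 and 2. The expected step is therefore a number 2 percentage points higher from compound 3 to compound 4 (within the scatter), within the scatter. Compound 4 is estimated at 13%, range 3% to 28%.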

Compound 4, a percentage reported as inhibition, in the whole organism at one dose (the size of the read-out at that dose, not a potency): 29%
Estimate against measurement, compound 4: 16 percentage points below; measured number outside the range, above it.
By their numbers in this assay, from the lowest: compounds 1, 3, 2 and 4 (each within the scatter of the next, the first and the last beyond it).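

Methyl on the nitrogen on the aromatic ring is the first change from the amino compound to give a step beyond the scatter (a number 18 percentage points higher from compound 3 to compound 4 (beyond the scatter)). Methylamino also separates from methoxy (a number 25 percentage points higher from compound 1 to compound 4 (beyond the scatter)), but not from methyl (a number 8 percentage points higher from compound 2 to compound 4 (within the scatter)), so the series shows no clear advantage for it over compound 2. No available evidence bears on this result.

Going by these compounds, whether a second methyl, as in dimethylamino, or a longer chain, as in ethylamino, keeps this step remains open. With one dose, the results speak only of a stronger or weaker effect at that dose.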